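A few compounds are considered here, and "the series" means these few. Any claim that something is new, unique, unknown or untested is made for them only; others in the source may bear on it.

Series notes. Compound 1 `Cc1c(Cn2ccnc2)sc2ccc(C(=O)O)cc12` and compound 2 `Cc1c(Cn2ccnc2)sc2cc(C(=O)O)ccc12` are built from the same atoms joined differently; the difference between the two cores is not broken down here. In an assay for inhibition of Thromboxane-A synthase (Homo sapiens) (on this read-out higher numbers stand for weaker inhibition and lower numbers for stronger inhibition), compound 1 gives 17 nM, and compound 2 gives 18 nM, the two numbers lying within the scatter of each other. Compound 3 `O=C(O)c1ccc2sc(Cn3ccnc3)c(Cl)c2c1` carries the change chloro in place of methyl on an aromatic carbon on the core of compound 1. In this assay compound 3 gives 22 nM. The step of a 1.3-fold higher number from compound 1 to compound 3 (0.11 log units; within the scatter) stays within the scatter.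

Compound 4 `O=C(O)c1ccc2c(Cl)c(Cn3ccnc3)sc2c1` has not yet been measured. It carries the change chloro in place of methyl on an aromatic carbon on the core of compound 2, the same change as in compound 3, described in identical words for its place. The change occurs twice among the compounds here, once with a measured result.

For compound 4 the expected step is a 1.3-fold higher number from compound 2 to compound 4 (0.11 log units; within the scatter), set beside a 1.3-fold higher number from compound 1 to compound 3 (0.11 log units; within the scatter). The expectation rests on that single measured step and on compound 2 standing at 18 nM within the scatter of compound 1. Compound 4 is expected to give 23 nM in this assay, with a range from 12 nM to 45 nM.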

Compound 4, half-maximal inhibitory concentration: 40 nM
Compound 4: middle estimate off by 1.7-fold (0.24 log units), on the low side, within the range that was stated.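

In this assay, chloro in place of methyl on an aromatic carbon gives a 2.2-fold higher number from compound 2 to compound 4 (0.35 log units; beyond the scatter), while the same change on the core of compound 1 stayed within the scatter. Set side by side, the two steps cannot be told apart: the same change on two cores in this assay, a 1.3-fold higher number (0.11 log units; within the scatter) from compound 1 to compound 3 and a 2.2-fold higher number (0.35 log units; beyond the scatter) from compound 2 to compound 4, 1.7-fold (0.23 log units) apart, within the scatter of two such steps. As far as these two cores go, the data therefore give no sign that the outcome of the change depends on the core, but two steps, one of them within the scatter, cannot show that it carries over unchanged, nor say anything about any other core.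

Still open, going by these compounds, is what other groups would do on this same aromatic carbon, such as ethyl, bromo or methoxy, and how a plain hydrogen there would compare with methyl and chloro. Also open, on these data alone, is how the series responds when the carboxylic acid gives way to an amide or a nitrile, or when the (1H-imidazol-1-yl)methyl group gives way to an amine.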